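A few compounds are considered here, and "the series" means these few. Any claim that something is new, unique, unknown or untested is made for them only; others in the source may bear on it.

Among the compounds with values here, compound 2, with structure `CC(C)(C)OC(=O)N1CCC(O[C@H]2CC[C@H](Oc3ccc(S(C)(=O)=O)cn3)CC2)CC1`, is one of two compounds measured in a functional assay on isolated protein for agonist activity at Glucose-dependent insulinotropic receptor (Rattus norvegicus), read by HTRF and cAMP accumulation (a lower number here means that less compound is needed, a higher number that more compound is needed for the effect), where compound 2 gives 110 nM. Within the data shown here, its only neighbour is compound 1, with structure `CC(C)(C)OC(=O)N1CCC(O[C@H]2CC[C@H](Oc3ccc(S(C)(=O)=O)cc3)CC2)CC1`, and in this assay compound 1 gives 94 nM; the two numbers lie within the scatter of each other, so neither can be called stronger. Among the measured compounds shown here, the one step between them, a 1.2-fold higher number from compound 1 to compound 2 (0.07 log units; within the scatter), swapped the ring on the oxygen on the saturated carbon and left the read-out essentially unchanged.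

Compound 3, with structure `CC(C)(C)OC(=O)N1CCC(O[C@H]2CC[C@H](Oc3cnc(S(C)(=O)=O)cn3)CC2)CC1`, carries the same kind of swap once more: 5-(methylsulfonyl)pyrazin-2-yl in place of 5-(methylsulfonyl)pyridin-2-yl on an oxygen on a saturated carbon. For the measured compounds named here, the single step that bears on this change was flat, so no movement beyond the scatter is expected, and the step from compound 2 to compound 3 is estimated at a 1.3-fold higher number from compound 2 to compound 3 (0.10 log units; within the scatter). Compound 3 is therefore expected to give about 140 nM in this assay, with a likely range from 60 nM to 330 nM.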

Compound 3, half-maximal effective concentration: 64 nM
Compound 3: middle estimate off by 2.2-fold (0.34 log units), on the high side; the range from low to high includes it.
By their numbers in this assay, from the lowest: compounds 3, 1 and 2 (each within the scatter of the next).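

Replacing the 5-(methylsulfonyl)pyridin-2-yl with a 5-(methylsulfonyl)pyrazin-2-yl on an oxygen on a saturated carbon keeps this assay within the scatter: the change gives a 1.7-fold lower number from compound 2 to compound 3 (0.24 log units; within the scatter) and, measured against the 4-(methylsulfonyl)phenyl, a 1.5-fold lower number from compound 1 to compound 3 (0.17 log units; within the scatter) as well. All three steps among these ring swaps now lie within the scatter, so this assay does not separate the three rings, and none of them can be called stronger than another. No evidence is available to explain why the numbers stay this close.

From the compounds shown here alone, all three compounds keep the methylsulfonyl group, and what a nitrile or a carboxylic acid in its place would do to the number remains open. Also open, going by these compounds, is whether any change at this position can move the read-out beyond the scatter.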